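Aryl exchange on compound 3: expectation for compound 4

A few compounds are considered here, and "the series" means these few. Any claim that something is new, unique, unknown or untested is made for them only; others in the source may bear on it.

Measured in a functional assay on BGC-823 cells (Homo sapiens) for inhibition, read by CCK-8 assay, with a stated time of 48 h; a lower number here means a stronger inhibitor, a higher number a weaker inhibitor:
- compound 1 `Fc1ccc(C2=NN(C3=NC(c4ccccc4)CS3)C(c3ccc4ccccc4c3)C2)cc1`: 17300 nM
- compound 2 `Cc1ccc(C2=NN(C3=NC(c4ccccc4)CS3)C(c3cccc4ccccc34)C2)cc1C`: 8460 nM
- compound 3 `Cc1ccc(C2=NN(C3=NC(c4ccccc4)CS3)C(c3ccc4ccccc4c3)C2)cc1C`: 6570 nM

Compound 3 gives the lowest of the three numbers. The step of a 1.3-fold lower number from compound 2 to compound 3 (0.11 log units; within the scatter) is within the scatter, so those two cannot be ordered; the step of a 2.6-fold lower number from compound 1 to compound 3 (0.42 log units; beyond the scatter) is beyond the scatter and is the only clear separation in the set.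

Compound 4 `Clc1ccc(C2=NN(C3=NC(c4ccccc4)CS3)C(c3ccc4ccccc4c3)C2)cc1` differs from compound 3 in one place: 4-chlorophenyl in place of 3,4-dimethylphenyl on a carbon with a double bond to nitrogen. Of the measured steps only a 2.6-fold lower number from compound 1 to compound 3 (0.42 log units; beyond the scatter) touches the same position, an exchange of the aryl group on the carbon with a double bond to nitrogen: 4-fluorophenyl went with the higher number, 3,4-dimethylphenyl with the lower one. Going by the values given here, compound 4 takes part of that exchange back, a halogen on the ring again in place of the two methyl groups, though chlorine rather than fluorine, for which no measured pair exists. The step of a 1.3-fold lower number from compound 2 to compound 3 (0.11 log units; within the scatter), on the saturated ring carbon, does not touch the changed position and gives no guidance. A modest rise of the number in this assay is expected, short of a full return to the number of compound 1, estimated as a 1.5-fold higher number from compound 3 to compound 4 (0.18 log units; within the scatter). For compound 4 the expected value is 10000 nM, with a range from 5000 nM to 25000 nM.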

Compound 4, half-maximal inhibitory concentration: 14600 nM
Beside the measured number, compound 4's estimate is 1.5-fold (0.16 log units) below it; the range from low to high includes it.
By their numbers in this assay, from the lowest: compounds 3, 2, 4 and 1 (each within the scatter of the next, the first and the last beyond it).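

In this assay, 4-chlorophenyl in place of 3,4-dimethylphenyl on the carbon with a double bond to nitrogen gives a 2.2-fold higher number from compound 3 to compound 4 (0.35 log units; beyond the scatter) and thereby adds a second exchange at this position to the single one available earlier. The two halogens themselves cannot be told apart: chloro in place of fluoro on the aromatic carbon gives a 1.2-fold lower number from compound 1 to compound 4 (0.07 log units; within the scatter) and so leaves no readable difference between compound 1 and compound 4. With naphthalen-2-yl held constant in compounds 1, 3 and 4, the separation at this position therefore lies between 3,4-dimethylphenyl and the two halogen-bearing phenyl groups, and not between the halogen-bearing groups themselves.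

Still open, on these data alone, is whether 4-methylphenyl, with a single methyl group, would fall with 3,4-dimethylphenyl or with the halogen-bearing groups, how an aryl group carrying an amine or a carboxylic acid would behave at this position, and whether the same separation holds with naphthalen-1-yl on the saturated ring carbon. No measurement available here accounts for the separation at this position.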